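The source may hold more compounds than are shown below. What is called first, only, known or untested is meant among the compounds shown, and "the series" means these compounds.

Compound 3 `COc1ccc(CN2C(=O)C(=O)c3cc(-c4cccc(OC)c4)ccc32)cc1` is one of three compounds with a shared core tested in a functional assay on K562 cells (Homo sapiens) for antiproliferative activity, read by MTT assay, with a stated time of 48 h; on this read-out higher numbers stand for weaker inhibition and lower numbers for stronger inhibition; in this assay compound 3 gives 100 nM, the second highest of the three numbers. Compound 1 `COc1ccc(-c2ccc3c(c2)C(=O)C(=O)N3Cc2ccc(OC)c(OC)c2)cc1` gives 60 nM, which lies within the scatter of the value of compound 3, and compound 2 `COc1ccc(-c2ccc3c(c2)C(=O)C(=O)N3Cc2ccc3ccccc3c2)cc1` gives 400 nM, beyond the scatter of both. Within the data shown here, the only measured step between compounds that differ in a single place, a 6.7-fold higher number from compound 1 to compound 2 (0.82 log units; beyond the scatter), concerns the group on the saturated chain carbon bound to the amide-type nitrogen in the ring, not the aryl substituent. Compound 4 `COc1ccc(CN2C(=O)C(=O)c3cc(-c4ccc(OC)c(OC)c4)ccc32)cc1` differs from compound 3 by methoxy in place of hydrogen on an aromatic carbon; cut one bond further out, the change reads 3-methoxyphenyl to 3,4-dimethoxyphenyl. Among the measured compounds shown here, no measured step touches that aryl position, and compound 1, although it also carries a methoxy group at a corresponding place on its aryl ring, differs from compound 3 at more than one point, so that pair cannot be read as a step. The step from compound 3 to compound 4 in this assay is therefore expected to be small, a 1.3-fold lower number from compound 3 to compound 4 (0.12 log units; within the scatter), with no clear direction beyond the scatter. Compound 4 is estimated at 75 nM, with a range from 25 nM to 220 nM.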

Compound 4, half-maximal inhibitory concentration: 260 nM
Compound 4: middle estimate off by 3.5-fold (0.54 log units), on the low side; measured number outside the range, above it.
By their numbers in this assay, from the lowest: compounds 1 and 3 (each within the scatter of the next); then compounds 4 and 2 (each within the scatter of the next).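

Placing a methoxy group on the aromatic carbon ortho to the existing methoxy group and para to a large group gives a 2.6-fold higher number from compound 3 to compound 4 (0.41 log units; beyond the scatter) in this assay, so this added methoxy weakens inhibition rather than leaving it unchanged. Among these compounds, this is the first step read on the aryl ring of the shared core, and it shows that this ring is also sensitive: until now, the only single-place change beyond the scatter was on the saturated chain carbon bound to the amide-type nitrogen, a 6.7-fold higher number from compound 1 to compound 2 (0.82 log units; beyond the scatter), and the two steps run in the same direction, toward weaker inhibition. Nothing in the data explains why the added methoxy has this effect.

The compounds shown leave open whether the loss follows from methoxy itself or from any group at this place, a question that a fluorine atom, a hydroxy group or an ethoxy group there could begin to settle. They also leave open whether the same loss would appear without the methoxy group already on the ring, as a lone 4-methoxyphenyl in the same setting would show.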